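The compounds below may be only part of what the source reports. "The series", "measured", "known", "first", "only" and "open" are said of these compounds alone.

Measured so far in a functional assay on NUGC-3 cells (Homo sapiens) for cytotoxicity, read by sulforhodamine B assay, with a stated time of 72 h; a lower number here means a stronger inhibitor of growth, a higher number a weaker inhibitor of growth:
compound 1 `O=C(Nc1ccccc1O)C1CCc2ccccc2N1C(=O)c1ccccc1Cl` gives 36800 nM
compound 2 `CCCC(=O)N1c2ccccc2CCC1C(=O)Nc1cc(C(F)(F)F)cc(C(F)(F)F)c1` gives 14400 nM
compound 3 `O=C(Nc1ccccc1C(F)(F)F)C1CCc2ccccc2N1` gives 39300 nM

Compound 3 holds the highest of the three numbers. Compound 1 lies within the usual scatter of it, so no order between these two can be read. Compound 2 sits beyond the scatter with the lower number. Within the data shown here, both compound 1 and compound 2 carry an acyl group that compound 3 lacks, but each also differs in the amide portion, so no single pair isolates the acylation and no measured step is available for it.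

Compound 4 `O=C(Nc1ccccc1C(F)(F)F)C1CCc2ccccc2N1C(=O)c1cccc(Cl)c1` introduces exactly that kind of change: (3-chlorophenyl)carbonyl in place of hydrogen on a nitrogen on an aromatic ring in a ring. Since the two acylated compounds give numbers at or below that of compound 3, the expectation leans towards a lower number for compound 4, of modest size and not assuredly beyond the scatter. The step from compound 3 to compound 4 in this assay is therefore estimated as a 2.0-fold lower number from compound 3 to compound 4 (0.29 log units; within the scatter). Compound 4 is expected to give about 20000 nM, with a likely range from 6000 nM to 60000 nM.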

Compound 4, concentration for 50% growth inhibition: 754 nM
Compound 4: the middle estimate sits 27-fold (1.42 log units) above what was measured, outside the stated range (below it).
By their numbers in this assay, from the lowest: compound 4; then compound 2; then compounds 1 and 3 (each within the scatter of the next).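

In this assay, among these compounds, (3-chlorophenyl)carbonyl in place of hydrogen on the nitrogen on an aromatic ring in a ring gives a 52-fold lower number from compound 3 to compound 4 (1.72 log units; beyond the scatter), the first measured step that isolates a change at this position. With the amide portion of compound 3 held fixed, growth inhibition therefore responds strongly to what this nitrogen carries, which compound 1 and compound 2 could not show, as each also differs from compound 3 in the amide portion. No measurement bearing on the origin of this step is available.

As far as these compounds go, it remains open whether the step belongs to the carbonyl, the aromatic ring, the chlorine or the place of the chlorine on that ring, and whether an acetyl group, an unsubstituted benzoyl group or a benzoyl group carrying an amine or a carboxylic acid would give a step of similar size on the same nitrogen. From the compounds shown here alone, it also remains open whether (3-chlorophenyl)carbonyl gives a comparable step when the trifluoromethyl-bearing amide portion of compound 3 is replaced by another.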